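Chloromethyl to chloropyridinyl on the amide carbonyl

The compounds below may be only part of what the source reports. "The series", "measured", "known", "first", "only" and "open" are said of these compounds alone.

Among the compounds with values here, compound 1 `O=C(Nc1ccc(Cl)cc1)c1cc([N+](=O)[O-])ccc1Cl` is the first member of the pair. In an ADME assay on BJ cells (Homo sapiens) for inhibition, with a stated time of 72 h (a lower number here means that less compound is needed, a higher number that more compound is needed for the effect), compound 1 gives > 25000 nM, which is a limit of the assay and not a number. Within the data shown here, compound 2 `O=C(CCl)Nc1cccc(-c2nc3ccccc3s2)c1` in this assay gives 8500 nM, the only number in the set. The other value sits at the limit of > 25000 nM in this assay, at which 1 of the 2 values shown sits. Compound 3 `O=C(Nc1cccc(-c2nc3ccccc3s2)c1)c1ccnc(Cl)c1` differs from compound 2 by 2-chloropyridin-4-yl in place of chloromethyl on a carbonyl carbon. Among the measured compounds shown here, no measured pair shows such a step; a shift toward more compound needed, beyond the scatter, is expected in this assay. For compound 3 the estimate is 16000 nM, within 4000 nM to 40000 nM. That corresponds to an expected step of a 1.9-fold higher number from compound 2 to compound 3 (0.27 log units; within the scatter).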

Compound 3, half-maximal effective concentration: > 25000 nM
Compound 3 gave a limit, no number (the forecaster's own chance of this, stated with the estimate: 35%); middle value at least 1.5-fold (0.19 log units) from the limit.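

In this assay, the group on the carbonyl carbon of this amide matters: 2-chloropyridin-4-yl in place of chloromethyl gives an at least 2.9-fold higher number from compound 2 to compound 3 (0.46 log units; beyond the scatter). The value of compound 3 is a limit of the assay and not a number, so the step has a lower bound but no known full size. This limit is now the most common reading in the set: the limit of > 25000 nM in this assay, at which 2 of the 3 values shown sit.

The compounds shown leave open whether the step follows from losing chloromethyl, gaining the ring or gaining its chlorine. Plain methyl, unsubstituted pyridin-4-yl or aminomethyl on this carbonyl would separate these.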